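This account rests on a few compounds, and the source may have more. Where it says the series, first, only, none or still open, it means among the compounds named here.

Working notes on the series.

Three compounds share one core and differ in a single substituent on the fused ring of the core. Compound 1 `O=C(Nc1ccc(-n2ncc3c(C(F)(F)F)cccc32)cc1)Nc1ccc(Cl)c(C(F)(F)F)c1` carries trifluoromethyl there; compound 2 `O=C(Nc1ccc(-n2ncc3c(Cl)cccc32)cc1)Nc1ccc(Cl)c(C(F)(F)F)c1` carries chloro; compound 3 `O=C(Nc1ccc(-n2ncc3c(Br)cccc32)cc1)Nc1ccc(Cl)c(C(F)(F)F)c1` carries bromo. In a functional assay on LoVo cells (Homo sapiens) for cytotoxicity, read by MTT assay, with a stated time of 72 h (on this read-out higher numbers stand for weaker inhibition and lower numbers for stronger inhibition), compound 1 gives 3000 nM, compound 2 gives 3600 nM, and compound 3 gives 1700 nM. Among the measured compounds shown here, compound 3 has the lowest of the three numbers, but only one of its steps stands apart: a 2.1-fold lower number from compound 2 to compound 3 (0.33 log units; beyond the scatter), whereas a 1.8-fold lower number from compound 1 to compound 3 (0.25 log units; within the scatter) and a 1.2-fold higher number from compound 1 to compound 2 (0.08 log units; within the scatter).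

Compound 4 `O=C(Nc1ccc(-n2ncc3c(F)cccc32)cc1)Nc1ccc(Cl)c(C(F)(F)F)c1` is the next member: fluoro in place of bromo on an aromatic carbon. For the measured compounds named here, the steps that bear on it are the two that end at compound 3, since each exchanges one substituent at this position for bromo, and both are small, one of them beyond the scatter only by a narrow margin. Nothing here shows a change at this position moving the number far in either direction. Going by the values given here, a fluoro substituent at this position has no precedent in the set, so the expectation for compound 4 is anchored on compound 3 and on the spread of the other two numbers.

Compound 4 is expected to give 3000 nM in this assay, with a range from 1500 nM to 7000 nM. The expected step is a 1.8-fold higher number from compound 3 to compound 4 (0.25 log units; within the scatter), a number somewhat higher than that of compound 3 and close to those of compound 1 and compound 2.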

Compound 4, half-maximal inhibitory concentration: 9800 nM
Estimate against measurement, compound 4: 3.3-fold (0.51 log units) below; measured number outside the range, above it.
By their numbers in this assay, from the lowest: compounds 3, 1 and 2 (each within the scatter of the next, the first and the last beyond it); then compound 4.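

Fluoro is the first exchange at this position in this assay to separate clearly from all the others, with compound 4 standing apart from each earlier compound (a 5.8-fold higher number from compound 3 to compound 4 (0.76 log units; beyond the scatter); a 2.7-fold higher number from compound 2 to compound 4 (0.43 log units; beyond the scatter); a 3.3-fold higher number from compound 1 to compound 4 (0.51 log units; beyond the scatter)). The position therefore does respond to a single-substituent exchange, which the narrow spread of compounds 1, 2 and 3 did not show, and the step from bromo is the largest of the three. Among the three halogens, the numbers rise from bromo in compound 3 through chloro in compound 2 to fluoro in compound 4, while trifluoromethyl in compound 1 lies within the scatter of both compound 2 and compound 3, so it does not separate from either of them. No measurement at hand accounts for the rise seen with fluoro.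

Going by these compounds, whether the halogen order extends to iodo, and where a methoxy group or an amine at this position would fall, remains open. Also open, on these data alone, is whether the step from bromo to fluoro keeps its size when the rest of the shared core is changed.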